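The compounds below may be only part of what the source reports. "The series", "measured", "known", "first", "only" and "open" are said of these compounds alone.

Measured compounds:
compound 1, `CCC(CC)CNc1c(C(N)=O)cnc2ccc(C#N)cc12`: 820 nM
compound 2, `C[C@@H](Nc1ccnc2ccc(-c3cccnc3)cc12)c1ccc(Cl)cc1`: > 30000 nM

The account concerns an assay on HT-29 cells for inhibition of Serine-protein kinase ATM (Homo sapiens), read by fluorescence, with a stated time of 1 h; on this read-out higher numbers stand for weaker inhibition and lower numbers for stronger inhibition. In this assay compound 1 gives 820 nM, the only number among the two results shown. Compound 2 stands only as a limit of the assay, > 30000 nM, and carries no number. Going by the values given here, compound 1 is therefore the one measured compound with a numerical result, and the other result, (the limit of > 30000 nM in this assay, at which 1 of the 2 values shown sits), is a limit that cannot be compared with it as a number; the two compounds also differ in more than one place, so no single step between them is traced.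

The unmeasured compound 3, `CCC(CC)CNc1c(C(N)=O)cnc2ccc(-c3ccc(COC)nc3)cc12`, shares the core of compound 1 and differs from it in one place: 6-(methoxymethyl)pyridin-3-yl in place of cyano on an aromatic carbon. With a larger aromatic group in place of the nitrile on the same aromatic carbon, the step from compound 1 to compound 3 is expected to be a gain in inhibition beyond the usual scatter, though with wide uncertainty, as no measured step of this kind is shown. The step of a 5.5-fold lower number from compound 1 to compound 3 (0.74 log units; beyond the scatter) is the expected change. Compound 3 is estimated at 150 nM, with a range from 30 nM to 1500 nM.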

Compound 3, half-maximal inhibitory concentration: 45 nM
For compound 3 the middle estimate is 3.3-fold (0.52 log units) above the measured one; the range from low to high includes it.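

In this assay, 6-(methoxymethyl)pyridin-3-yl in place of cyano gives an 18-fold lower number from compound 1 to compound 3 (1.26 log units; beyond the scatter), so this aromatic carbon of the shared core can carry a group of 9 heavy atoms, including a six-membered aromatic ring, with inhibition far stronger than with the nitrile. Going by these compounds alone, until this result, the core of compound 1 had been seen with the nitrile alone, and nothing showed how inhibition would respond to a change at this position. The information shown does not account for the size of this step.

From the compounds shown here alone, the ring and the methoxymethyl group enter together, so their separate shares in the step remain open, and a plain phenyl, an unsubstituted pyridin-3-yl or a pyridin-3-yl bearing an amine in place of the methoxymethyl group would be needed to separate them. Going by these compounds, the chain on the amine and the carboxamide are the same in compound 1 and compound 3, so it also remains open what a shorter chain or a carboxylic acid in place of the carboxamide would do alongside the new group.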